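Urea series on the shared core: cytotoxicity working notes

A few compounds are considered here, and "the series" means these few. Any claim that something is new, unique, unknown or untested is made for them only; others in the source may bear on it.

Measured so far:
compound 1 `CSc1ccc(NC(=O)Nc2cc(C)nc3ccccc23)cc1` — 24000 nM
compound 2 `Cc1cc(NC(=O)Nc2cnc3ccccc3c2)c2ccccc2n1` — > 25000 nM
compound 3 `Cc1cc(NC(=O)Nc2cccc(N(C)C)c2)c2ccccc2n1` — > 25000 nM

In an ADME assay on HEK293 cells (Homo sapiens) for cytotoxicity, with a stated time of 72 h (a higher number here means that more compound is needed for the effect, a lower number that less compound is needed), compound 1 gives 24000 nM. For compound 2 the assay reports only a limit, > 25000 nM. For compound 3 the assay likewise reports only a limit, > 25000 nM. Going by the values given here, compound 1 therefore holds the only numerical value in the set; the other two values sit at the limit of > 25000 nM in this assay, at which 2 of the 3 values shown sit. The number for compound 1 lies close to that limit.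

Compound 4 `Cc1cc(NC(=O)Nc2ccc(N)cc2)c2ccccc2n1` is not yet measured. It differs from compound 1 in one place: amino in place of methylsulfanyl on an aromatic carbon. The change sits on an aromatic carbon of a six-membered aromatic ring of carbon only, para to a large group. Among the compounds with values here, no two measured compounds differ from each other in a single place, so no measured step in this assay is available to guide the expectation, and the set gives no pattern that the change could be read against.

The step expected in this assay is a 1.0-fold higher number from compound 1 to compound 4 (0.02 log units; within the scatter), which is within the usual scatter. For compound 4 the estimated value is 25000 nM, with a range from 12000 nM to 50000 nM. Since compound 1 already lies near the limit, a fair chance remains that only a limit, and no number, is reported for compound 4.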

Compound 4, half-maximal effective concentration: > 25000 nM
Compound 4 ended at the assay's limit; the forecaster's own chance of this, stated with the estimate: 50%; the middle value lies on the limit itself.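

In this assay, going by these compounds alone, amino in place of methylsulfanyl on an aromatic carbon, para to a large group, gives the first step between two compounds that differ in one place: an at least 1.0-fold higher number from compound 1 to compound 4 (0.01 log units; that floor lies within the scatter). For compound 4 the result is a limit, > 25000 nM, and not a number, so this step gives only a floor, and that floor lies within the scatter; the data therefore cannot say whether this change shifts the number at all or by how much. The true size of the step cannot be read because the reading for compound 4 stops at the same limit as most of the set: the limit of > 25000 nM in this assay, at which 3 of the 4 values shown sit.

Compound 1 remains the only compound with a numerical value, so the compounds shown give no measured step of known size at this position and no sign of which groups there would give a number well clear of the limit. As far as these compounds go, how a carboxylic acid or a longer chain such as butylsulfanyl on this same aromatic carbon would read in this assay remains open.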